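The source may hold more compounds than are shown below. What is called first, only, known or untested is meant among the compounds shown, and "the series" means these compounds.

Measured compounds:
- compound 1 `O=C(Nc1ccccc1F)N1CCN(c2ccnc(Cl)n2)CC1`, 787 nM
- compound 2 `O=C(Nc1cccc(F)c1)N1CCN(c2ccnc(Cl)n2)CC1`, 952 nM
- compound 3 `O=C(Nc1ccc(Cl)cc1)N1CCN(c2ccnc(Cl)n2)CC1`, 1250 nM

All three were measured in an assay on isolated protein for antagonist activity at transient receptor potential cation channel subfamily V member 1 (Homo sapiens); a higher number here means a weaker inhibitor, a lower number a stronger inhibitor. Compound 1 gives the lowest of the three numbers, but its gap to compound 2 is a 1.2-fold higher number from compound 1 to compound 2 (0.08 log units; within the scatter) and its gap to compound 3 is a 1.6-fold higher number from compound 1 to compound 3 (0.20 log units; within the scatter), both within the scatter, so no order among the three can be read from these values. The remaining step, a 1.3-fold higher number from compound 2 to compound 3 (0.12 log units; within the scatter), is likewise within the scatter.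

Compound 4 `O=C(Nc1ccccc1[N+](=O)[O-])N1CCN(c2ccnc(Cl)n2)CC1` is not yet measured. It differs from compound 1 in one place: nitro in place of fluoro on an aromatic carbon. The three measured steps all swap the substituent on the aromatic ring attached to the amide-type nitrogen, and each of them stayed within the scatter. None of them introduces a nitro, so the step to compound 4 has no direct precedent, yet the pattern shown by compound 1, compound 2 and compound 3 is that changing this substituent has moved this assay little. The expectation is therefore a step of a 1.3-fold higher number from compound 1 to compound 4 (0.10 log units; within the scatter), not beyond the scatter, in either direction. Compound 4 is estimated at 1000 nM in this assay, with a range of 400 nM to 2500 nM.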

Compound 4, half-maximal inhibitory concentration: 854 nM
Compound 4: the middle estimate sits 1.2-fold (0.07 log units) above what was measured, within the range that was stated.
By their numbers in this assay, from the lowest: compounds 1, 4, 2 and 3 (each within the scatter of the next).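

In this assay, placing nitro in place of fluoro on an aromatic carbon, ortho to a large group, gives a 1.1-fold higher number from compound 1 to compound 4 (0.04 log units; within the scatter) and so adds a different kind of substituent to a series that otherwise carried only fluoro or chloro on this ring. Within the data shown here, the new step shows that, at this one place, fluoro with its 1 heavy atom and 0 hydrogen-bond acceptors can give way to nitro with its 3 heavy atoms and 2 hydrogen-bond acceptors without a step beyond the scatter, a larger change in the group than any of the earlier steps made. No measurement at hand bears on why the number stays within the scatter after this exchange.

The compounds shown leave open whether this tolerance extends to an amine, a carboxylic acid or a longer chain such as butoxy at the same place, since all four compounds carry only fluoro, chloro or nitro on this ring. They also leave open whether a nitro at another place on the ring, or any change to the shared core, would move the number beyond the scatter.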